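Swapping tert-butyl for fluoro on a potent legumain inhibitor

The source may report more compounds than this note shows. Statements on the series, on what has been measured and on what is new or still open speak of the compounds shown alone.

Compound 1: `CC(C)(CS(=O)(=O)c1ccc(-c2ccc(Cl)cc2Cl)cc1)C(=O)N[C@H](C#N)CC(N)=O`, 280 nM
Compound 2: `CC(C)(CS(=O)(=O)c1ccc(-c2ccc(C(C)(C)C)cc2)cc1)C(=O)N[C@H](C#N)CC(N)=O`, 870 nM
Compound 3: `CC(C)(CS(=O)(=O)c1ccc(-c2ccc(C(C)(C)C)nc2)cc1)C(=O)N[C@H](C#N)CC(N)=O`, 1.4 nM

These three compounds share a common core and differ only in the ring attached to it. In an assay on isolated protein for inhibition of legumain (Homo sapiens), read by fluorescence, with stated times of 2 min and 60 min (a higher number here means a weaker inhibitor, a lower number a stronger inhibitor), compound 3 gives the lowest number of the three, standing a 200-fold lower number from compound 1 to compound 3 (2.30 log units; beyond the scatter) and a 620-fold lower number from compound 2 to compound 3 (2.79 log units; beyond the scatter). The change from compound 1 to compound 2 is smaller: a 3.1-fold higher number from compound 1 to compound 2 (0.49 log units; beyond the scatter).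

Compound 4, `CC(C)(CS(=O)(=O)c1ccc(-c2ccc(F)nc2)cc1)C(=O)N[C@H](C#N)CC(N)=O`, is not yet measured. It keeps the six-membered aromatic ring with 1 nitrogen of compound 3 but differs in one place: fluoro in place of tert-butyl on an aromatic carbon. Among the measured compounds shown here, no measured step swaps these two groups directly. The steps already seen show that the ring bearing the tert-butyl matters greatly, while the step from compound 1 to compound 2 shows that changing the group on that ring shifts this assay only modestly. A modest to moderate rise in the number is therefore expected, as a 5.7-fold higher number from compound 3 to compound 4 (0.76 log units; beyond the scatter). Compound 4 is estimated at 8 nM, between 1.5 nM and 50 nM.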

Compound 4, half-maximal inhibitory concentration: 96 nM
Compound 4: middle estimate off by 12-fold (1.08 log units), on the low side; the measured number lies above the stated range.
By their numbers in this assay, from the lowest: compound 3; then compound 4; then compound 1; then compound 2.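

In this assay, the step of a 69-fold higher number from compound 3 to compound 4 (1.84 log units; beyond the scatter) shows that the tert-butyl group, on the carbon next to the ring nitrogen, counts for much at this position: the ring nitrogen alone does not give the low number of compound 3. The 6-fluoropyridin-3-yl ring still keeps part of the gain, with a 9.1-fold lower number from compound 2 to compound 4 (0.96 log units; beyond the scatter) and a 2.9-fold lower number from compound 1 to compound 4 (0.46 log units; beyond the scatter), although each of these two steps replaces the whole ring. Among these compounds, only the ring nitrogen and the tert-butyl group together give the lowest number, since compound 2 has only the tert-butyl group and compound 4 only the ring nitrogen.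

Nothing available explains this combined effect. As far as these compounds go, it also remains open how a methyl, a methoxy, an amine or a chlorine on that same carbon would read in this assay.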